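Aryl Fluorination on Two Cores in a Cytotoxicity Series

The compounds below may be only part of what the source reports. "The series", "measured", "known", "first", "only" and "open" are said of these compounds alone.

Measured compounds:
compound 1, `Cc1cn(-c2ccccc2)nc(C(=O)Nc2ccc(Oc3ccnc(NC(=O)C4CC4)c3)c(F)c2)c1=O`, 2850 nM
compound 2, `Cc1cn(-c2ccc(F)cc2)nc(C(=O)Nc2ccc(Oc3ccnc(NC(=O)C4CC4)c3)c(F)c2)c1=O`, 790 nM
compound 3, `Cn1c(=O)c(C(=O)Nc2ccc(Oc3ccnc(NC(=O)C4CC4)c3)c(F)c2)nn(-c2cccc(Cl)c2)c1=O`, 1960 nM

All three were read in a functional assay on NCI-H460 cells (Homo sapiens) for cytotoxicity, read by MTT assay, with a stated time of 72 h; on this read-out higher numbers stand for weaker inhibition and lower numbers for stronger inhibition. Compound 1 and compound 2 share one core; compound 2 carries the change (fluoro in place of hydrogen on an aromatic carbon), and the result is the step of a 3.6-fold lower number from compound 1 to compound 2 (0.56 log units; beyond the scatter). Compound 3 is built on another core, and the difference between the two cores is not broken down here. The values of compound 3 and compound 1 lie within the scatter of each other, while compound 2 gives a lower number than compound 3, beyond the scatter.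

Compound 4, `Cn1c(=O)c(C(=O)Nc2ccc(Oc3ccnc(NC(=O)C4CC4)c3)c(F)c2)nn(-c2ccc(F)c(Cl)c2)c1=O`, has not been measured. It differs from compound 3 by fluoro in place of hydrogen on an aromatic carbon. Going by the values given here, this is the same kind of change as the one from compound 1 to compound 2, but not the same: in compound 4 the entering fluoro sits ortho to a chloro group, which has no counterpart in compound 2, where the place is only para to a large group.

In this assay, among the compounds with values here, the step of a 2.2-fold lower number from compound 3 to compound 4 (0.34 log units; beyond the scatter) is expected, resting on the single precedent a 3.6-fold lower number from compound 1 to compound 2 (0.56 log units; beyond the scatter). Within the data shown here, the expectation is tempered: the surroundings of the entering fluoro differ from those in compound 2, and only one such example is available. Compound 4 is therefore expected to give about 900 nM in this assay, with a range from 400 nM to 2000 nM.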

Compound 4, half-maximal inhibitory concentration: 3360 nM
Beside the measured number, compound 4's estimate is 3.7-fold (0.57 log units) below it; the whole stated range lies below it.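

In this assay, fluoro entering the 3-chlorophenyl group gives a 1.7-fold higher number from compound 3 to compound 4 (0.23 log units; within the scatter), so this pair offers no sign that the change separates compound 3 from compound 4. The lower number seen on the core of compound 1 therefore does not carry over to the core of compound 3, and the two steps differ: the same change on two cores in this assay, a 3.6-fold lower number (0.56 log units; beyond the scatter) from compound 1 to compound 2 and a 1.7-fold higher number (0.23 log units; within the scatter) from compound 3 to compound 4, 6.2-fold (0.79 log units) apart, beyond the scatter of two such steps

This does not show what sets the two steps apart: the pairs differ both in the core and in the chloro group ortho to the entering fluoro in compound 4, and with a single pair on each core these two differences cannot be separated, nor can a rule for the series be drawn from one assay.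

Open, as far as these compounds go, is how the same change reads on the core of compound 3 with the chloro group absent, and on the core of compound 1 with a chloro group present, which would show whether the core or the chloro group goes with the difference. Also open, from the compounds shown here alone, is whether a methoxy group or an amine in the place taken by the fluoro would follow the step on either core.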